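The source may report more compounds than this note shows. Statements on the series, on what has been measured and on what is new or still open speak of the compounds shown alone.

Measured compounds:
compound 1 `O=C(/C=C/c1ccc(Cl)c(Cl)c1)c1ccc(N2C(=O)C=CC2=O)cc1`: 7700 nM
compound 2 `Cc1ccc(/C=C/C(=O)c2ccc(N3C(=O)C=CC3=O)cc2)cc1`: 4100 nM

Among the measured compounds shown here, in a functional assay on CCRF-CEM cells (Homo sapiens) for cytotoxicity (on this read-out higher numbers stand for weaker inhibition and lower numbers for stronger inhibition), compound 2 gives 4100 nM, and compound 1 gives 7700 nM; the two numbers lie within the usual scatter of each other, as the single measured step, a 1.9-fold lower number from compound 1 to compound 2 (0.27 log units; within the scatter), shows. Compound 3 `O=C(O)c1ccc(/C=C/C(=O)c2ccc(N3C(=O)C=CC3=O)cc2)cc1` differs from compound 2 by carboxy in place of methyl on an aromatic carbon. For the measured compounds named here, the one measured step concerns the same ring, but it exchanges one aryl substitution pattern for another and introduces no carboxy, so it gives no direction for the present change; it only shows that a change on this ring left the number within the scatter. Compound 3 is therefore expected to show a 1.2-fold higher number from compound 2 to compound 3 (0.09 log units; within the scatter), a step not beyond the scatter, with wide uncertainty because only a 1.9-fold lower number from compound 1 to compound 2 (0.27 log units; within the scatter) is available. Compound 3 is estimated at 5000 nM, in the range 1500 nM to 20000 nM.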

Compound 3, half-maximal inhibitory concentration: 133000 nM
Beside the measured number, compound 3's estimate is 27-fold (1.42 log units) below it; measured number outside the range, above it.
By their numbers in this assay, from the lowest: compounds 2 and 1 (each within the scatter of the next); then compound 3.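

In this assay carboxy in place of methyl on the aromatic carbon gives a 32-fold higher number from compound 2 to compound 3 (1.51 log units; beyond the scatter) and so moves the number far more than the earlier exchange on this ring, which gave a 1.9-fold lower number from compound 1 to compound 2 (0.27 log units; within the scatter) and stayed within the scatter. This position is therefore not indifferent to what it carries, and the entry of carboxy, with its hydrogen-bond donor and acceptor, goes with much weaker inhibition than either methyl or the dichlorinated ring of compound 1 shows. The compounds shown offer no evidence on why the number rises so far.

They leave open whether the step belongs to the carboxylic acid as such, which a methyl ester or a primary amide on the same carbon would test. An amine there, or a longer chain ending in the carboxylic acid, also remains to be placed against compound 2.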